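A Methyl Group in Place of Hydrogen on Compound 3

This account rests on a few compounds, and the source may have more. Where it says the series, first, only, none or still open, it means among the compounds named here.

Going by the values given here, in a functional assay on HT-29 cells (Homo sapiens) for cytotoxicity (a lower number here means a stronger inhibitor, a higher number a weaker inhibitor), compound 3 (`CC(C)=CCCc1ccc2c(c1)C(=O)C=CC2=O`) gives 1000 nM, the lowest of the three numbers measured so far. Compound 1 (`CC(=O)Oc1ccc(OC(C)=O)c2c1CC=C(CCC=C(C)C)C2`) gives 3600 nM, and compound 2 (`CC(=O)Oc1cc(C)c(OC(C)=O)c2c1CC=C(CCC=C(C)C)C2`) gives 14600 nM. Compound 4 (`CC(C)=CCCc1ccc2c(c1)C(=O)C(C)=CC2=O`) has not yet been measured. It differs from compound 3 by one change, methyl in place of hydrogen on a double-bonded ring carbon. Among the compounds with values here, only one measured step bears on this change, a 4.1-fold higher number from compound 1 to compound 2 (0.61 log units; beyond the scatter), a modest rise beyond the scatter, seen when methyl replaced hydrogen on an aromatic carbon. Within the data shown here, that step lies on a different kind of carbon, so it serves only as a loose guide, and the data hold no direct example of the new placement. A somewhat smaller rise in this assay is therefore expected, estimated as a 2.2-fold higher number from compound 3 to compound 4 (0.34 log units; beyond the scatter). Compound 4 is estimated at 2200 nM, with an expected range from 800 nM to 6500 nM.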

Compound 4, half-maximal inhibitory concentration: 19600 nM
Compound 4: the middle estimate sits 8.9-fold (0.95 log units) below what was measured; the measured number lies above the stated range.
By their numbers in this assay, from the lowest: compound 3; then compound 1; then compounds 2 and 4 (each within the scatter of the next).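

In this assay, methyl on the double-bonded ring carbon of the six-membered non-aromatic ring costs far more than methyl on the aromatic carbon did: a 20-fold higher number from compound 3 to compound 4 (1.29 log units; beyond the scatter) is a large step, against the modest 4.1-fold higher number from compound 1 to compound 2 (0.61 log units; beyond the scatter). The same replacement of hydrogen by methyl therefore does not carry one size of effect from one kind of ring carbon to the other, at least across these two pairs. Nothing measured here accounts for the size of this step.

The compounds shown carry only hydrogen or methyl at this carbon, so it stays open whether ethyl, methoxy or chlorine there would give a similar rise. On these data alone, it also stays open whether methyl at this carbon would have the same effect with a shorter alkyl chain in place of the chain that compound 3 and compound 4 share.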